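The source may hold more compounds than are shown below. What is called first, only, known or untested is meant among the compounds shown, and "the series" means these compounds.

For the measured compounds named here, compound 3 `N#Cc1cccc(C(=O)N2CCc3nc(C#Cc4ccccc4)sc3C2)c1` gives 71 nM in an assay on HEK293 cells for positive allosteric modulation of metabotropic glutamate receptor 5 (Homo sapiens), read by FLIPR, with a stated time of 1 h (on this read-out higher numbers stand for an effect only at larger amounts of compound and lower numbers for an effect already at smaller amounts), the lowest of the three numbers measured so far, though its gap to compound 2 `CC1CCCC(C(=O)N2CCc3nc(C#Cc4ccccc4)sc3C2)C1`, which gives 100 nM, is within the scatter; only the gap to compound 1 `O=C(C1CCCCC1)N1CCc2nc(C#Cc3ccccc3)sc2C1`, which gives 167 nM, is beyond it. Compound 4 `O=C(N1CCC(F)CC1)N1CCc2nc(C#Cc3ccccc3)sc2C1` differs from compound 3 by 4-fluoropiperidin-1-yl in place of 3-cyanophenyl on a carbonyl carbon. Going by the values given here, two measured steps bear on this: a 2.4-fold lower number from compound 1 to compound 3 (0.37 log units; beyond the scatter) and a 1.4-fold lower number from compound 2 to compound 3 (0.15 log units; within the scatter), both moving from a saturated ring to the aromatic one. Reversing that direction towards a saturated ring, the step from compound 3 to compound 4 is expected to be modest and upward, a 2.1-fold higher number from compound 3 to compound 4 (0.32 log units; beyond the scatter). Compound 4 is therefore estimated at 150 nM, with a range from 60 nM to 400 nM.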

Compound 4, half-maximal effective concentration: 74 nM
For compound 4 the middle estimate is 2.0-fold (0.31 log units) above the measured one; low and high end bracket the measured number.
By their numbers in this assay, from the lowest: compounds 3, 4, 2 and 1 (each within the scatter of the next, the first and the last beyond it).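

A saturated ring on this carbonyl carbon can sit level with the aromatic 3-cyanophenyl: the change to 4-fluoropiperidin-1-yl gives a 1.0-fold higher number from compound 3 to compound 4 (0.02 log units; within the scatter) and so stays within the scatter. Among the saturated rings, a 1.4-fold lower number from compound 2 to compound 4 (0.13 log units; within the scatter) is also within the scatter, while a 2.3-fold lower number from compound 1 to compound 4 (0.35 log units; beyond the scatter) is beyond it, so a saturated ring alone does not settle the outcome. The compounds shown cannot separate the part played by the ring nitrogen from that of the fluorine, which a plain piperidin-1-yl on the same carbonyl carbon would address. Nothing available here explains these values.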